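This account rests on a few compounds, and the source may have more. Where it says the series, first, only, none or still open, it means among the compounds named here.

Measured compounds in an ADME assay on HEK293 cells (Homo sapiens) for cytotoxicity, read by reporter gene assay and resazurin assay, with a stated time of 48 h; a higher number here means that more compound is tolerated, a lower number that less compound is tolerated:
compound 1 `O=C(Nc1ccc(Sc2nc3ccccc3s2)cc1)c1cc(Br)cc(Br)c1O`, 66000 nM
compound 2 `O=C(Nc1ccc(Sc2nc3ccccc3s2)c(Cl)c1)c1cccc(Br)c1`, a limit of the assay, > 100000 nM
compound 3 `O=C(Nc1ccc(Sc2nc3ccccc3s2)c(Cl)c1)c1cccc(Br)c1O`, 64000 nM

Compound 1 gives the highest of the two numbers in this assay, and compound 3 sits nearest to it, a gap that lies within the scatter. Compound 2 does not give a number; its value is a limit of the assay, and the limit of > 100000 nM in this assay, at which 1 of the 3 values shown sits, is the only such limit among the three values.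

The piece follows the step from compound 1 to compound 4 `COc1ccccc1C(=O)Nc1ccc(Sc2nc3ccccc3s2)cc1`. The change is 2-methoxyphenyl in place of 3,5-dibromo-2-hydroxyphenyl on a carbonyl carbon. Going by the values given here, the one measured step, an at least 1.5-fold lower number from compound 2 to compound 3 (0.19 log units; that floor lies within the scatter), is the only one that touches the same amide-side ring: adding a hydroxy there gave a number where before there was only a limit. The step from compound 1 to compound 4 removes a hydroxy and two bromines and brings in a methoxy, so the direction in this assay would, if anything, be toward a higher number, but the measured step is small and its floor lies within the scatter.

Compound 4 is therefore expected to give 90000 nM in this assay, with a range from 40000 nM to 200000 nM. That estimate means an expected step of a 1.4-fold higher number from compound 1 to compound 4 (0.13 log units; within the scatter), which may well turn out as a limit rather than a number.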

Compound 4, half-maximal cytotoxic concentration: > 100000 nM
Compound 4 was reported as a limit; the forecaster's own chance of this, stated with the estimate: 40%; middle value at least 1.1-fold (0.04 log units) from the limit.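

In this assay, putting 2-methoxyphenyl in place of 3,5-dibromo-2-hydroxyphenyl on the carbonyl carbon gives an at least 1.5-fold higher number from compound 1 to compound 4 (0.18 log units; that floor lies within the scatter), so this change can be read only as a floor, and that floor does not reach beyond the scatter. Compound 4 is reported as a limit of the assay, and the count of values at that limit rises with it: the limit of > 100000 nM in this assay, at which 2 of the 4 values shown sit. The earlier compounds shown here showed only a single hydroxy exchanged for hydrogen on this ring, whereas this change takes away the hydroxy and both bromines together and brings in the methoxy, so the step shows how the whole group behaves and cannot be divided among its parts.

The compounds shown leave open which part of the change carries the step, since a ring with the two bromines but no hydroxy, or with the hydroxy alone, is not among them. They also leave open how the number would respond at this position to a different kind of group on the ring, such as an amine or a carboxylic acid in place of the methoxy.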